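Compound 1 without its aminomethyl group

This account rests on a few compounds, and the source may have more. Where it says the series, first, only, none or still open, it means among the compounds named here.

In an ADME assay on a cell-free system (plasma, Homo sapiens) for protein binding, read by LC-MS, with a stated time of 1 h, tested at 10 uM, compound 1 `NCc1ccc(NC(=O)N(CCCCO)Cc2ccc(C(=O)NO)cc2)cc1` gives 1.9%. Compound 2 `CCCCN(Cc1ccc(C(=O)NO)cc1)C(=O)Nc1ccc(CN)cc1`, with hydrogen in place of hydroxy on a saturated chain carbon, gives 47%. That difference amounts to a 1.9-fold lower unbound fraction from compound 1 to compound 2 (0.27 log units; within the scatter), which stays within the usual scatter.

Compound 3 `O=C(NO)c1ccc(CN(CCCCO)C(=O)Nc2ccccc2)cc1` keeps the hydroxy group and differs elsewhere: hydrogen in place of aminomethyl on an aromatic carbon. Among the measured compounds shown here, no measured step touches the aminomethyl group, so the only guide is a change at another place, the step to compound 2 of a 1.9-fold lower unbound fraction from compound 1 to compound 2 (0.27 log units; within the scatter). A step of no greater size is therefore expected, in the same direction, and it would probably not exceed the scatter. The expected change is a 1.3-fold lower unbound fraction from compound 1 to compound 3 (0.12 log units; within the scatter). For compound 3 the estimated value is 25%, with an expected range from 5% to 60%.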

Compound 3, plasma protein binding: 48%
Compound 3: the middle estimate sits 1.4-fold (0.16 log units) (unbound fraction) above what was measured, and the stated range covers the measured number.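

Among the compounds shown here, for the first time, a measured step touches the aminomethyl group on the aromatic carbon para to a large group: in this assay, hydrogen in its place gives a 1.9-fold lower unbound fraction from compound 1 to compound 3 (0.28 log units; within the scatter) as the step. The two compounds therefore cannot be told apart in this read-out, and with the hydroxy group kept on the chain, this single pair gives no sign that the aminomethyl group matters for plasma protein binding. No independent measurement bears on this result.

Still open, going by these compounds, is whether a different group on the same aromatic carbon, such as a carboxylic acid, a methoxy group or a longer aminoethyl chain, would also stay within the scatter. On these data alone, it is also open what the same removal of aminomethyl does on the core of compound 2, whose chain has no hydroxy group.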